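Chloro for Methoxy on a Shared Indole-Oxadiazole Core

The compounds below may be only part of what the source reports. "The series", "measured", "known", "first", "only" and "open" are said of these compounds alone.

Compound 1 `c1ccc(-c2nnc(-c3c[nH]c4ccccc34)o2)cc1`: > 1000000 nM, a limit in a functional assay on MIA PaCa-2 cells (Homo sapiens) for cytotoxicity, read by MTT assay; on this read-out lower numbers stand for stronger inhibition and higher numbers for weaker inhibition
Compound 2 `c1ccc(Cc2nnc(-c3c[nH]c4ccccc34)o2)cc1`: 934000 nM
Compound 3 `COc1ccc(-c2nnc(-c3c[nH]c4ccccc34)o2)cc1`: > 1000000 nM, a limit

Compound 3 stands at the limit of this assay, which it shares with compound 1 (the limit of > 1000000 nM in this assay, at which 2 of the 3 values shown sit). Compound 4 `Clc1ccc(-c2nnc(-c3c[nH]c4ccccc34)o2)cc1` differs from it by chloro in place of methoxy on an aromatic carbon. Among the compounds with values here, no measured step swaps one small group for another on that ring: the step of an at least 1.0-fold lower number from compound 1 to compound 2 (0.02 log units; that floor lies within the scatter) lies within the scatter, and the step that the two limits leave unreadable from compound 1 to compound 3 cannot be sized. With nothing pointing to a real change, the expected step of a number no higher from compound 3 to compound 4 (the limit leaves the size open) is none beyond the scatter. Compound 4 is therefore estimated at 1000000 nM, with a range from 300000 nM to 3000000 nM, most likely again reported only as a limit.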

Compound 4, half-maximal inhibitory concentration: 6460000 nM
For compound 4 the middle estimate is 6.5-fold (0.81 log units) below the measured one; measured number above the stated range.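

Compound 4, with chloro on the aromatic ring para to a large group, gives a measured number, whereas compound 3, with methoxy there, has only a limit. Within the data shown here, the one readable step is a 6.9-fold higher number from compound 2 to compound 4 (0.84 log units; beyond the scatter), so 4-chlorophenyl in place of benzyl weakens inhibition in this assay. The steps from compound 1 and from compound 3 to compound 4 cannot be read, because those two compounds have only limits: the limit of > 1000000 nM in this assay, at which 2 of the 4 values shown sit.

From the compounds shown here alone, whether chloro truly differs from methoxy or hydrogen here stays open. So does whether an amine or a carboxylic acid at this position would bring the number down.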